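Trading an Amidrazone for a Thioamide on a Nucleoside Core

The compounds below may be only part of what the source reports. "The series", "measured", "known", "first", "only" and "open" are said of these compounds alone.

Of the compounds shown here, three have been tested in a functional assay on KB cells (Homo sapiens) for inhibition; a higher number here means a weaker inhibitor, a lower number a stronger inhibitor. Compound 1, `N=C(NN)c1cn([C@@H]2O[C@H](CO)[C@@H](O)[C@H]2O)c2nnnc(N)c12`, gives 3000 nM and so holds the lowest number of the two actual values. Compound 2, `Cc1ccc(C(=O)OC[C@H]2O[C@@H](n3cc(C(N)=O)c(C(N)=O)c3N)C[C@@H]2OC(=O)c2ccc(C)cc2)cc1`, gives 100000 nM, which lies well beyond the scatter from compound 1. Compound 3, `CN(N)c1nnnc2c1c(C#N)cn2[C@@H]1O[C@H](COC(=O)c2ccccc2)[C@@H](OC(=O)c2ccccc2)[C@H]1OC(=O)c1ccccc1`, returns only a limit of the assay, > 10000 nM, rather than a number; one of the three values is such a limit, as noted in the limit of > 10000 nM in this assay, at which 1 of the 3 values shown sits.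

The next compound keeps the sugar and the fused core of compound 1 and alters only one substituent. Compound 4, `NC(=S)c1cn([C@@H]2O[C@H](CO)[C@@H](O)[C@H]2O)c2nnnc(N)c12`, carries a different group on an aromatic carbon of the five-membered ring:

a group of 3 heavy atoms (1 carbon, 1 nitrogen, 1 sulfur; no ring) in place of a group of 4 heavy atoms (1 carbon, 3 nitrogen; no ring), on an aromatic carbon

Going by the values given here, no pair of measured compounds differs in a single place, so no measured step shows what such a swap does here. The structure of compound 4 stays close to that of compound 1 in size and in the hydrogen-bonding groups it keeps, so only a modest step in this assay is expected, within or near the scatter, in either direction. My estimate is that the step from compound 1 to compound 4 comes out as a 1.5-fold lower number from compound 1 to compound 4 (0.18 log units; within the scatter). For compound 4 the expected value in this assay is 2000 nM, with a range from 300 nM to 15000 nM.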

Compound 4, half-maximal inhibitory concentration: 2000 nM
Compound 4: the middle estimate sits on the measured number at the digits printed, within the range that was stated.
By their numbers in this assay, from the lowest: compounds 4 and 1 (each within the scatter of the next); then compound 2.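

Going by these compounds alone, this is the first step in this assay that can be read at all, with compound 1 and compound 4 differing in one place only: on an aromatic carbon of the five-membered aromatic ring, a thioamide replaces an amidrazone, giving a 1.5-fold lower number from compound 1 to compound 4 (0.18 log units; within the scatter). This position therefore takes a group with sulfur in place of two of the nitrogens, and with fewer hydrogen-bond donors and acceptors, while the two compounds remain indistinguishable in this read-out, so the full set of amidrazone donors and acceptors is not required here for activity at this level. Within the data shown here, nothing measured so far gives a reason for this result.

As far as these compounds go, what remains open is how far this tolerance extends, since two closely matched groups cannot show whether a carboxylic acid, a simple amine or a longer chain on the same carbon would also leave the number in this assay unchanged. From the compounds shown here alone, compound 2 and compound 3 differ from compound 1 in more than one place, so neither helps to answer that question, and whether any change at this carbon can move the number beyond the scatter is still unknown.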